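The source may report more compounds than this note shows. Statements on the series, on what has been measured and on what is new or still open speak of the compounds shown alone.

Compound 3 `CCCS(=O)(=O)Nc1ccc(F)c(C(=O)c2n[nH]c3ncc(-c4ccc(Cl)c(C(F)(F)F)c4)cc23)c1F` gives 15% in an assay for binding affinity to dual specificity mitogen-activated protein kinase kinase 4 (Homo sapiens), read by KINOMEscan, tested at 100 nM (a higher number here means a weaker effect of the compound at the concentration tested, a lower number a stronger effect), and stands second highest of the three numbers measured: compound 1 `CCCS(=O)(=O)Nc1ccc(F)c(C(=O)c2n[nH]c3ncc(-c4ccc(O)cc4)cc23)c1F` gives 0.75%, while compound 2 `CCCS(=O)(=O)Nc1ccc(F)c(C(=O)c2n[nH]c3ncc(-c4cccc(N(C)C)c4)cc23)c1F` gives 26%. Compound 4 `CCCS(=O)(=O)Nc1ccc(F)c(C(=O)c2n[nH]c3ncc(-c4ccc(S(=O)(=O)NCC)cc4)cc23)c1F` differs from compound 3 in one place (4-(ethylsulfamoyl)phenyl in place of 4-chloro-3-(trifluoromethyl)phenyl on an aromatic carbon). Every measured step swaps the same ring at this position: a number 25.3 percentage points higher from compound 1 to compound 2 (beyond the scatter), a number 14.3 percentage points higher from compound 1 to compound 3 (beyond the scatter) and a number 11 percentage points lower from compound 2 to compound 3 (beyond the scatter) were all modest. Since the 4-hydroxyphenyl of compound 1 brought the lowest number 0.75% and the entering group likewise carries a hydrogen-bond donor, a modest downward step in this assay is expected, though nothing measured fixes its size. Compound 4 is expected to give about 6%, between 0.5% and 40%, which means an estimated step of a number 9 percentage points lower from compound 3 to compound 4 (within the scatter).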

Compound 4, a percentage reported as activity, at one concentration (the size of the read-out at that concentration, not a potency): 3%
Estimate against measurement, compound 4: 3 percentage points above, within the range that was stated.
By their numbers in this assay, from the lowest: compounds 1 and 4 (each within the scatter of the next); then compound 3; then compound 2.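

Placing 4-(ethylsulfamoyl)phenyl at this position gives a number 12 percentage points lower from compound 3 to compound 4 (beyond the scatter) and a number 23 percentage points lower from compound 2 to compound 4 (beyond the scatter), while swapping hydroxy for ethylsulfamoyl gives a number 2.3 percentage points higher from compound 1 to compound 4 (within the scatter) and so shows no difference that can be told from scatter. For the compounds shown here, compound 1 and compound 4, which both carry a hydrogen-bond donor on this ring, now sit together at the low end, and compound 2 and compound 3, which carry none, lie higher, with no compound here going against that pattern. No measured evidence here explains this pattern.

Four compounds cannot show whether the donor itself matters. Going by these compounds, a ring bearing an amine or a carboxylic acid, or a sulfonamide with a longer chain than ethyl, remains open.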